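The source may hold more compounds than are shown below. What is called first, only, known or untested is meant among the compounds shown, and "the series" means these compounds.

Measured so far:
compound 1 `Nc1ccc(S(=O)(=O)Nc2ccnc3cc(C(F)(F)F)ccc23)cc1`: 53700 nM
compound 2 `O=S(=O)(Nc1nccs1)c1ccc(N/C(S)=N\c2ccnc3cc(C(F)(F)F)ccc23)cc1`: 67100 nM

Both values come from a functional assay on LoVo cells (Homo sapiens) for antiproliferative activity, read by sulforhodamine B assay, with a stated time of 48 h; a lower number here means a stronger inhibitor, a higher number a weaker inhibitor. Compound 2 has the highest of the two numbers, but its gap to compound 1 lies within the scatter, so the two cannot be told apart. Compound 3 `COc1ncnc(NS(=O)(=O)c2ccc(N/C(S)=N\c3ccnc4cc(C(F)(F)F)ccc34)cc2)c1OC` differs from compound 2 in one place: 5,6-dimethoxypyrimidin-4-yl in place of 1,3-thiazol-2-yl on a sulfonamide nitrogen. Within the data shown here, no measured pair shows this change, so its effect is unknown. The step from compound 2 to compound 3 in this assay is expected to be small, not beyond the scatter, giving a 1.1-fold lower number from compound 2 to compound 3 (0.05 log units; within the scatter). Compound 3 is therefore estimated at 60000 nM in this assay, with a range from 20000 nM to 180000 nM.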

Compound 3, half-maximal inhibitory concentration: 28400 nM
Compound 3: the middle estimate sits 2.1-fold (0.32 log units) above what was measured; low and high end bracket the measured number.
By their numbers in this assay, from the lowest: compounds 3, 1 and 2 (each within the scatter of the next, the first and the last beyond it).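

In this assay the group on the sulfonamide nitrogen can shift the result: 5,6-dimethoxypyrimidin-4-yl in place of 1,3-thiazol-2-yl gives a 2.4-fold lower number from compound 2 to compound 3 (0.37 log units; beyond the scatter) as a modest step, the only one here that lies beyond the scatter. The change swaps a five-membered ring for a six-membered one and adds two methoxy groups at once, so this single step cannot separate those parts. No measurement at hand says what lies behind the step.

Going by these compounds, it remains open whether the ring or the methoxy groups carry the step. A pyrimidin-4-yl without methoxy groups, or a phenyl on the same nitrogen, would help separate them.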